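The source may report more compounds than this note shows. Statements on the series, on what has been measured and on what is new or still open speak of the compounds shown alone.

Measured so far:
- compound 1 `CC1CCN(c2c(S(=O)(=O)c3cccc(F)c3)cnc3ccc(Cl)cc23)CC1`: in an assay on isolated protein for displacement of a labelled ligand from metabotropic glutamate receptor 5 (Homo sapiens), with a stated time of 60 min, tested at 1 uM (a lower number here means less inhibition, a higher number more inhibition at the concentration tested (going by the name of the read-out)), compound 1 gives 58%
- compound 2 `COc1ccc2ncc(S(=O)(=O)c3cccc(C#N)c3)c(N3CCC(C)CC3)c2c1`: in this assay compound 2 gives 90%
- compound 3 `Cc1ccc2ncc(S(=O)(=O)c3ccc(F)cc3)c(N3CCC(C)CC3)c2c1`: in this assay compound 3 gives 90%

Compound 2 stands level with compound 3 at the digits shown, the two together being the highest of the three numbers, with no change between them beyond the scatter. Compound 1 lies furthest from compound 2, a gap beyond the scatter.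

The next compound, compound 4 `COc1ccc2ncc(S(=O)(=O)c3ccc(Cl)cc3)c(N3CCC(C)CC3)c2c1`, keeps the core of compound 2 and differs only on the sulfonyl sulfur: 4-chlorophenyl in place of 3-cyanophenyl on a sulfonyl sulfur.

Among the measured compounds shown here, no step between measured compounds covers this change. Compound 3 carries 4-fluorophenyl on the same sulfur and gives 90%, the same level as compound 2, so a step of about none beyond the scatter is expected, with a modest downward lean allowed because compound 1 gives 58% with a different aryl and core. The expected step is a number 5 percentage points lower from compound 2 to compound 4 (within the scatter). For compound 4 the estimate in this assay is 85%, within 65% to 96%.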

Compound 4, a percentage reported as inhibition, at one concentration (the size of the read-out at that concentration, not a potency): 91%
The estimate for compound 4 lay 6 percentage points below the measured number, and the stated range covers the measured number.
By their numbers in this assay, from the lowest: compound 1; then compounds 2, 3 and 4 (each within the scatter of the next).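

With the shared core held, 4-chlorophenyl in place of 3-cyanophenyl on a sulfonyl sulfur gives a number 1 percentage points higher from compound 2 to compound 4 (within the scatter) in this assay, the first step read at this position. The nitrile is therefore not required to hold the level of compound 2 in this series, although a single-concentration percentage could hide a difference in potency between the two compounds. No measurement on hand explains this result.

Open, from the compounds shown here alone, is whether the sulfonyl sulfur accepts anything other than a substituted phenyl, such as a longer alkyl chain, or a phenyl carrying an amine or a carboxylic acid. Also open, going by these compounds, is the source of the lower number of compound 1 at 58%, since compound 1 differs from the others in more than one place.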